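Aryl change on the ring nitrogen: compound 3 to compound 4

The source may hold more compounds than are shown below. What is called first, only, known or untested is meant among the compounds shown, and "the series" means these compounds.

Compound 3 `FC(F)(F)c1ccc(CSc2nc(Nc3ccc(Cl)cc3)c3ccccc3n2)cc1` gives 14100 nM in a functional assay on HGC-27 cells (Homo sapiens) for cytotoxicity, read by MTT assay, with a stated time of 72 h (a higher number here means a weaker inhibitor, a lower number a stronger inhibitor), the lowest of the two numbers shown. Compound 2 `Cc1ccccc1Nc1nc(SCc2ccc(C(F)(F)F)cc2)nc2ccccc12` gives 27500 nM in this assay, and the data show a 2.0-fold lower number from compound 2 to compound 3 (0.29 log units; within the scatter). For compound 1 `FC(F)(F)c1ccc(CSc2nc(Nc3ccccc3C(F)(F)F)c3ccccc3n2)cc1` this assay reports > 50000 nM, which is the limit of > 50000 nM in this assay, at which 1 of the 3 values shown sits, a limit and not a number.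

Compound 4 `COc1cc(Nc2nc(SCc3ccc(C(F)(F)F)cc3)nc3ccccc23)cc(OC)c1` differs from compound 3 by 3,5-dimethoxyphenyl in place of 4-chlorophenyl on a nitrogen on an aromatic ring. The measured changes at the same nitrogen read an at least 3.5-fold lower number from compound 1 to compound 3 (0.54 log units; beyond the scatter) and a 2.0-fold lower number from compound 2 to compound 3 (0.29 log units; within the scatter); neither involves a methoxy group, so no direction is supported. Compound 4 is therefore expected to give 14000 nM, with a range from 4500 nM to 45000 nM. This amounts to an expected 1.0-fold lower number from compound 3 to compound 4 (0.00 log units; within the scatter), nothing beyond the scatter.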

Compound 4, half-maximal inhibitory concentration: > 50000 nM
Compound 4: only a limit was reported; the forecaster's own chance of this, stated with the estimate: 15%; at least 3.5-fold (0.55 log units) between middle value and limit.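

Going by these compounds alone, at this nitrogen, the earlier steps all ended at compound 3; 3,5-dimethoxyphenyl in place of 4-chlorophenyl now gives an at least 3.5-fold higher number from compound 3 to compound 4 (0.54 log units; beyond the scatter) and shows that an aryl change here can also raise the number beyond the scatter. The comparison with compound 2 is less firm, with an at least 1.8-fold higher number from compound 2 to compound 4 (0.25 log units; that floor lies within the scatter) as the step. Compound 4 gives a limit and not a number, and the step between compound 1 and compound 4 cannot be read: the limit of > 50000 nM in this assay, at which 2 of the 4 values shown sit.

As far as these compounds go, whether a hydroxyl or an amine on this phenyl ring would keep the number near that of compound 3 remains open. The compounds shown also do not separate the effect of the methoxy groups from that of losing the chlorine.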